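The source may report more compounds than this note shows. Statements on the series, on what has been measured and on what is new or still open speak of the compounds shown alone.

Compound 1 `COc1ccc(-c2c(C)[nH]c(=O)n2C)cc1` gives 147000 nM in a functional assay on brain (Rattus norvegicus, strain Wistar) for inhibition; on this read-out higher numbers stand for weaker inhibition and lower numbers for stronger inhibition. Compound 2 `CCCCCCCCOc1ccc(-c2c(C)[nH]c(=O)n2C)cc1` gives 4000 nM, and compound 3 `COc1ccc(-c2c(C)[nH]c(=O)n2C2CCCCC2)cc1` gives 20400 nM, the second highest of the three numbers, standing between the other two. Compound 4 `Cc1[nH]c(=O)n(C2CCCCC2)c1-c1ccc(Oc2ccccc2)cc1` has not been measured; it differs from compound 3 by phenyl in place of methyl on an oxygen on an aromatic ring. Within the data shown here, one measured step bears on this: a larger group on the same oxygen gave a 37-fold lower number from compound 1 to compound 2 (1.57 log units; beyond the scatter), a large change. The present change enlarges that position by fewer atoms, so a smaller but still clear gain is expected, a 4.5-fold lower number from compound 3 to compound 4 (0.66 log units; beyond the scatter). Compound 4 is therefore expected to give about 4500 nM, with a likely range of 1200 nM to 15000 nM.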

Compound 4, half-maximal inhibitory concentration: 7900 nM
The estimate for compound 4 lay 1.8-fold (0.24 log units) below the measured number; the measured number falls inside the stated range.
By their numbers in this assay, from the lowest: compounds 2 and 4 (each within the scatter of the next); then compound 3; then compound 1.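

Phenyl in place of methyl on the oxygen gave a 2.6-fold lower number from compound 3 to compound 4 (0.41 log units; beyond the scatter) as a modest step. An aromatic ring on this oxygen, and not only a saturated chain, therefore goes with a lower number, and the position still responds with cyclohexyl on the aromatic nitrogen. No available evidence explains the size of this step.

From the compounds shown here alone, it remains open whether a benzyl group or a longer chain on this oxygen would lower the number further with cyclohexyl kept on the aromatic nitrogen. Going by these compounds, the effect of an amine or a carboxylic acid on the added phenyl also remains open.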